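A few compounds are considered here, and "the series" means these few. Any claim that something is new, unique, unknown or untested is made for them only; others in the source may bear on it.

Measured compounds:
Compound 1 `COc1cc(-c2cc(/C=C/C(=O)c3ccc(N)cc3)[nH]n2)cc(OC)c1OC` gives 7910 nM in a functional assay on OVCAR-5 cells (Homo sapiens) for inhibition, read by sulforhodamine B assay, with a stated time of 48 h; on this read-out higher numbers stand for lower toxicity in this test and lower numbers for higher toxicity in this test.
Compound 2 `COc1ccc(C(=O)/C=C/c2cc(-c3cc(OC)c(OC)c(OC)c3)n[nH]2)cc1OC` gives 5750 nM in this assay.
Compound 3 `COc1ccc(C(=O)/C=C/c2cc(-c3cc(OC)c(OC)c(OC)c3)n[nH]2)cc1` gives 7600 nM in this assay.

The three measured compounds lie close together: a 1.4-fold lower number from compound 1 to compound 2 (0.14 log units; within the scatter), a 1.0-fold lower number from compound 1 to compound 3 (0.02 log units; within the scatter) and a 1.3-fold higher number from compound 2 to compound 3 (0.12 log units; within the scatter), each within the scatter, so none of them can be set apart from the others on this read-out.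

Compound 4 `COc1ccc(-c2cc(/C=C/C(=O)c3ccc(N)cc3)[nH]n2)cc1OC` has not yet been measured in this assay. It is related to compound 1 by the change (hydrogen in place of methoxy on an aromatic carbon). The same kind of change is already seen between two measured compounds, from compound 2 to compound 3: hydrogen in place of methoxy on an aromatic carbon. That change made a 1.3-fold higher number from compound 2 to compound 3 (0.12 log units; within the scatter). The surroundings are not identical, though: in compound 1 the carbon that loses its methoxy is also meta to a methoxy group, which is not so in compound 2. The two cores also differ, as 4-aminophenyl in place of 3,4-dimethoxyphenyl on a carbonyl carbon.

Given that the measured change of this kind stayed within the scatter, the step expected from compound 1 to compound 4 is estimated as a 1.2-fold higher number from compound 1 to compound 4 (0.08 log units; within the scatter), resting on compound 1 at 7910 nM and on the size of a 1.3-fold higher number from compound 2 to compound 3 (0.12 log units; within the scatter). Compound 4 is therefore expected to give about 9500 nM in this assay, with a likely range from 5000 nM to 18000 nM.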

Compound 4, concentration lethal to 50% of the cells: 36300 nM
The estimate for compound 4 lay 3.8-fold (0.58 log units) below the measured number, and the stated range ends below it.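

In this assay, putting hydrogen in place of methoxy on the aromatic carbon gave a 4.6-fold higher number from compound 1 to compound 4 (0.66 log units; beyond the scatter), so on the core of compound 1 this change lowers toxicity in this test by more than the usual scatter. The same change therefore did not carry over at the same size from one core to the other: the same change on two cores in this assay, a 1.3-fold higher number (0.12 log units; within the scatter) from compound 2 to compound 3 and a 4.6-fold higher number (0.66 log units; beyond the scatter) from compound 1 to compound 4, 3.5-fold (0.54 log units) apart, beyond the scatter of two such steps. Among these compounds, this rests on only two pairs, which differ both in the group on the carbonyl carbon (4-aminophenyl or 3,4-dimethoxyphenyl) and in the surroundings of the carbon that loses its methoxy, so it does not show which of these differences matters, nor how large the change would be on any further core.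

The compounds shown leave open whether a hydroxyl group or a longer chain such as ethoxy on that aromatic carbon would give a number close to that of compound 1 or to that of compound 4. They also leave open whether the larger step belongs to the 4-aminophenyl group specifically, something a matched pair carrying a 4-hydroxyphenyl group on the carbonyl carbon could help to test.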